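Aryl swap on the oxazole of compound 1

The source may report more compounds than this note shows. Statements on the series, on what has been measured and on what is new or still open speak of the compounds shown alone.

For the measured compounds named here, compound 1, `Cc1oc(-c2c(Br)cccc2Br)nc1CN1CCC(C(=O)NCCCN2C[C@H](C)C[C@H](C)C2)CC1`, is the shorter-lived of the two compounds measured so far. In an ADME assay on microsomes from liver (Rattus norvegicus) for metabolic stability, read by LC-MS, using NADPH, at 37 degrees C (on this read-out lower numbers stand for a shorter-lived compound and higher numbers for a longer-lived compound), compound 1 gives 0.035 h, the lowest of the two numbers. Compound 2, `Cc1ccccc1-c1nc(CN2CCC(C(=O)NCCCCN3C[C@H](C)C[C@H](C)C3)CC2)c(C)o1`, differs from compound 1 in more than one place. In this assay compound 2 gives 0.2 h, a higher number, beyond the scatter.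

Compound 3, `Cc1ccc(-c2nc(CN3CCC(C(=O)NCCCN4C[C@H](C)C[C@H](C)C4)CC3)c(C)o2)cc1C`, remains to be measured in this assay. Against compound 1 the structural change is 3,4-dimethylphenyl in place of 2,6-dibromophenyl on an aromatic carbon.

Going by the values given here, with no single-change step available, the size of the change from compound 1 to compound 3 can only be guessed. A modest rise is expected, a 2.6-fold higher number from compound 1 to compound 3 (0.41 log units; beyond the scatter), in the direction of compound 2 but not necessarily beyond the scatter. Compound 3 is estimated to give 0.09 h, with the expected range between 0.03 h and 0.3 h.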

Compound 3, half-life: > 0.5 h
Compound 3: only a limit was reported; the forecaster's own chance of this, stated with the estimate: 5%; middle value at least 5.5-fold (0.74 log units) from the limit.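

Working from a single change, the aryl group on the five-membered aromatic ring with 1 nitrogen and 1 oxygen strongly affects the read-out in this assay: 3,4-dimethylphenyl in place of 2,6-dibromophenyl gives an at least 14-fold higher number from compound 1 to compound 3 (1.15 log units; beyond the scatter). The full size of this step cannot be read, as the value for compound 3 is a limit of the assay: the limit of > 0.5 h in this assay, at which 1 of the 3 values shown sits.

Compound 2 differs from compound 1 in more than one place, so this is the only step shown that isolates the aryl group.

The swap changes both the substituent and its place on the ring, and 2,6-dimethylphenyl or 3,4-dibromophenyl would separate the two. As far as these compounds go, whether unsubstituted phenyl at this position gives a similar read-out also remains open.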